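The source may hold more compounds than are shown below. What is called first, only, known or untested is meant among the compounds shown, and "the series" means these compounds.

Measured so far in a functional assay on HeLa cells (Homo sapiens) for cytotoxicity, read by cell counting, with a stated time of 4 days; a higher number here means a weaker inhibitor, a lower number a stronger inhibitor:

compound 1, `Nc1ccc(/C=C2\SC(=O)N(Cc3ccc(C(F)(F)F)cc3)C2=O)cc1`: 96000 nM
compound 2, `Nc1ccc(/C=C2\SC(=O)N(Cc3ccc(Cl)cc3)C2=O)cc1`: 77000 nM
compound 3, `Nc1cccc(/C=C2\SC(=O)N(Cc3ccc(C(F)(F)F)cc3)C2=O)c1`: a limit of the assay only, > 250000 nM

Compound 1 and compound 2 share a core and differ only by chloro in place of trifluoromethyl on an aromatic carbon; this change gave a 1.2-fold lower number from compound 1 to compound 2 (0.10 log units; within the scatter), so the two values cannot be told apart. Compound 3 carries a different core, and the difference between the two cores is 3-aminophenyl in place of 4-aminophenyl on a double-bonded chain carbon bound to a double-bonded ring carbon; the step of an at least 2.6-fold higher number from compound 1 to compound 3 (0.41 log units; beyond the scatter) is beyond the scatter and reaches the edge of the assay, which is the level marked by the limit of > 250000 nM in this assay, at which 1 of the 3 values shown sits. For compound 3 the assay gives only this limit, not a number.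

Compound 4, `Nc1cccc(/C=C2\SC(=O)N(Cc3ccc(Cl)cc3)C2=O)c1`, has not yet been measured. It stands to compound 3 as compound 2 stands to compound 1: the change is chloro in place of trifluoromethyl on an aromatic carbon, the same change as between compound 1 and compound 2, at the same place on the same ring. That earlier occurrence moved the value by a 1.2-fold lower number from compound 1 to compound 2 (0.10 log units; within the scatter), within the scatter. Among the measured compounds shown here, with only one measured instance of the change, and that one flat, the expectation is that compound 4 stays where compound 3 sits.

Compound 4 is therefore expected to give 300000 nM in this assay, and most probably again only a limit rather than a number. The step expected from compound 3 to compound 4 is a step that the limit leaves unreadable from compound 3 to compound 4, resting on the flat step seen from compound 1 to compound 2, a 1.2-fold lower number from compound 1 to compound 2 (0.10 log units; within the scatter). The plausible range expected for compound 4 is estimated to run from 150000 nM to 600000 nM.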

Compound 4, half-maximal inhibitory concentration: > 250000 nM
Compound 4 was reported as a limit (the forecaster's own chance of this, stated with the estimate: 70%); the middle value does not contradict the limit.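

With chloro in place of trifluoromethyl on the other aromatic ring, 3-aminophenyl in place of 4-aminophenyl in this assay gives an at least 3.2-fold higher number from compound 2 to compound 4 (0.51 log units; beyond the scatter), so the change points the same way on both cores and stays beyond the scatter on each: the same change on two cores in this assay, an at least 2.6-fold higher number (0.41 log units; beyond the scatter) from compound 1 to compound 3 and an at least 3.2-fold higher number (0.51 log units; beyond the scatter) from compound 2 to compound 4; the limit leaves it open whether they differ

Both steps are bounded on one side only, so neither their true size nor any difference between them can be taken from these compounds, with both 3-aminophenyl compounds sitting at the edge of the assay: the limit of > 250000 nM in this assay, at which 2 of the 4 values shown sit.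

On these data alone, the step between compound 3 and compound 4 cannot be read, so the flat result of chloro in place of trifluoromethyl on the 4-aminophenyl core, a 1.2-fold lower number from compound 1 to compound 2 (0.10 log units; within the scatter), is neither confirmed nor contradicted on the 3-aminophenyl core, and carrying that change from one core to the other remains untested.

The series as shown has only an amine on the aromatic ring of the double-bonded chain, so it leaves open whether a hydroxyl group, a carboxylic acid or a nitrile in that place would follow the same trend between the 4-substituted and 3-substituted forms. Also open, as far as these compounds go, is whether a group other than chloro or trifluoromethyl on the other aromatic ring, such as a methoxy group or a longer alkyl chain, would bring a 3-aminophenyl compound to a readable number.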